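Chloro for methoxy in the shared core series

The compounds below may be only part of what the source reports. "The series", "measured", "known", "first", "only" and "open" are said of these compounds alone.

Measured in an in vitro ADME assay on microsomes from liver (Homo sapiens) for metabolic stability; on this read-out lower numbers stand for slow clearance and higher numbers for fast clearance:
compound 1 `COCc1ccccc1C1CCc2nc[nH]c2C1`: < 7 mL.min-1.g-1; < 7 mL.min-1.g-1 (2 entries) (two entries, each a limit and not a number)
compound 2 `COc1cccc(C2CCc3nc[nH]c3C2)c1`: "not determined" (no result reported)
compound 3 `COc1ccc(C2Cc3nccn3C2)cc1`: 30 mL.min-1.g-1

Compound 2 has no number in this assay, so it offers no starting value for the step followed here. Compound 4 `Clc1cccc(C2CCc3nc[nH]c3C2)c1` is still to be measured. The step is chloro in place of methoxy on an aromatic carbon.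

Within the data shown here, no measured pair in this small set differs in one place, so the data give no direct size for such a change. The step from the methoxy compound to the chloro compound cannot be read from the numbers, and no direction can be favoured. A small change, not clearly beyond the usual scatter of this assay, is the working expectation.

The core of compound 2 is shared with compound 1, whose result is < 7 mL.min-1.g-1; < 7 mL.min-1.g-1 (2 entries), a limit and not a number. Compound 3 has a different core and gives 30 mL.min-1.g-1. Among the measured compounds shown here, these two results are the only guides, and the shared core carries more weight, so the expectation sits towards the low end of the measured range. For compound 4 the estimated value is 12 mL.min-1.g-1, with an expected range from 7 mL.min-1.g-1 to 35 mL.min-1.g-1.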

Compound 4, intrinsic clearance in microsomes in the Homo sapiens assay: 21 mL.min-1.g-1
Estimate against measurement, compound 4: 1.8-fold (0.24 log units) below; low and high end bracket the measured number.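

In the Homo sapiens assay compound 2 is recorded as "not determined" (no result reported), so no step can be read from compound 2 to compound 4, and compound 4 at 21 mL.min-1.g-1 stands without a partner. The compounds shown leave open both the size and the direction of any change in clearance with chloro in place of methoxy on an aromatic carbon. In a physicochemical assay for lipophilicity, at pH 7.4 (a lower number here means a more polar compound, a higher number a more lipophilic compound), compound 2 gives 2.6 and compound 4 gives 3.3.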